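Halogen swap on the azetidine series: chloro for fluoro

The source may report more compounds than this note shows. Statements on the series, on what has been measured and on what is new or still open speak of the compounds shown alone.

For the measured compounds named here, compound 3 `Fc1ncc(OC[C@@H]2CCN2)cc1-c1cccnc1` gives 0.066 nM in an assay on membranes from brain with Neuronal acetylcholine receptor; alpha4/beta2 (Rattus norvegicus) as the target (on this read-out lower numbers stand for stronger inhibition and higher numbers for weaker inhibition), and stands highest of the three numbers measured so far. Going by the values given here, compound 1 `Clc1ncc(OC[C@@H]2CCCN2)cc1-c1cccnc1` gives 0.021 nM in this assay, and compound 2 `Clc1ncc(OC[C@@H]2CCN2)cc1/C=C/c1ccncc1` gives 0.009 nM; both gaps to compound 3 lie beyond the scatter, but neither pair differs in only one place, so no single step can be drawn. Compound 4 `Clc1ncc(OC[C@@H]2CCN2)cc1-c1cccnc1` is not yet measured; it differs from compound 3 by chloro in place of fluoro on an aromatic carbon. Compound 1 carries chloro at the same site and shows 0.021 nM, so a step toward lower numbers, of moderate size, is expected. The estimate for compound 4 is 0.025 nM within 0.008 nM to 0.08 nM, which amounts to an expected step of a 2.6-fold lower number from compound 3 to compound 4 (0.42 log units; beyond the scatter).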

Compound 4, inhibition constant: 0.0081 nM
Beside the measured number, compound 4's estimate is 3.1-fold (0.49 log units) above it; low and high end bracket the measured number.
By their numbers in this assay, from the lowest: compounds 4 and 2 (each within the scatter of the next); then compound 1; then compound 3.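

In this assay the halogen on the aromatic carbon next to the ring nitrogen matters: chloro in place of fluoro gives an 8.1-fold lower number from compound 3 to compound 4 (0.91 log units; beyond the scatter) with the rest of the compound held fixed. With chloro kept, azetidin-2-yl in place of pyrrolidin-2-yl gives a 2.6-fold lower number from compound 1 to compound 4 (0.41 log units; beyond the scatter) as a smaller step, so both places move the number. Nothing at hand accounts for either step. Open, from the compounds shown here alone, is how bromo, methyl or nitrile would read at the halogen site. Also open, going by these compounds, is whether the azetidin-2-yl step holds with fluoro there.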